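The source may report more compounds than this note shows. Statements on the series, on what has been measured and on what is new or still open speak of the compounds shown alone.

Among the compounds with values here, compound 2 `CC1=C(/C=C/C(C)=C/C=C/C(C)=C\C(=O)Nc2ccccc2O)C(C)(C)CCC1n1ccnc1` gives 4670 nM in a functional assay on MDA-MB-231 cells (Homo sapiens) for inhibition, read by MTT assay (a higher number here means a weaker inhibitor of growth, a lower number a stronger inhibitor of growth), the highest of the two numbers measured so far. Its nearest neighbour is compound 1 `CC1=C(/C=C/C(C)=C/C=C/C(C)=C\C(=O)NCc2cccc(F)c2)C(C)(C)CCC1n1ccnc1`, which in this assay gives 1650 nM; the two differ only on the amide-type nitrogen, and that change brought a 2.8-fold higher number from compound 1 to compound 2 (0.45 log units; beyond the scatter). Compound 3 `CC1=C(/C=C/C(C)=C/C=C/C(C)=C\C(=O)NCc2ccccc2)C(C)(C)CCC1n1ccnc1` differs from compound 2 by benzyl in place of 2-hydroxyphenyl on an amide-type nitrogen. Within the data shown here, the single measured step that bears on this change is the one between compound 1 and compound 2. Benzyl and 3-fluorobenzyl are close relatives, and 2-hydroxyphenyl is the group given up in both comparisons. That step went upward by a modest amount, and the present change runs the other way, so a step downward of comparable size is expected, namely a 2.5-fold lower number from compound 2 to compound 3 (0.39 log units; beyond the scatter). Compound 3 is therefore estimated at 1900 nM in this assay, with a range from 900 nM to 4500 nM.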

Compound 3, concentration for 50% growth inhibition: 5880 nM
Estimate against measurement, compound 3: 3.1-fold (0.49 log units) below, and the stated range ends below it.
By their numbers in this assay, from the lowest: compound 1; then compounds 2 and 3 (each within the scatter of the next).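

In this assay the exchange of 2-hydroxyphenyl for benzyl on the amide-type nitrogen gives a 1.3-fold higher number from compound 2 to compound 3 (0.10 log units; within the scatter), so at this position the two groups cannot be told apart. Hydrogen in place of fluoro on an aromatic carbon instead brings a 3.6-fold higher number from compound 1 to compound 3 (0.55 log units; beyond the scatter), which shows that compound 1 stands apart from compound 3 through the fluoro on its 3-fluorobenzyl group alone. Nothing available explains either result.

The compounds shown leave open whether chloro, methoxy or an amine in place of that fluoro would keep the lower number of compound 1. They also leave open how an unsubstituted phenyl or a longer chain such as 2-phenylethyl on the amide-type nitrogen would compare.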